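Removing the aryl iodide from a methylene lactone carbamate

The source may hold more compounds than are shown below. What is called first, only, known or untested is meant among the compounds shown, and "the series" means these compounds.

Compound 1, `C=C1C(=O)OC[C@H]1CCOC(=O)Nc1ccc(I)cc1`, gives 12800 nM in an ADME assay on RAW264.7 cells (Mus musculus) for cytotoxicity, read by MTT assay, with a stated time of 18 h; a higher number here means that more compound is tolerated, a lower number that less compound is tolerated.
Compound 2, `C=C1C(=O)OC[C@@H]1CCOC(=O)Nc1ccc(I)cc1`, gives 12500 nM in this assay.

Compound 2 stands at the lower of the two numbers, but its neighbour compound 1 is a 1.0-fold lower number from compound 1 to compound 2 (0.01 log units; within the scatter), and the two differ only (the fact that compounds 1 and 2 differ only in the configuration as drawn). Compound 3, `C=C1C(=O)OC[C@@H]1CCOC(=O)Nc1ccccc1`, differs from compound 2 by hydrogen in place of iodo on an aromatic carbon. Among the measured compounds shown here, no measured step touches the aromatic ring: the single known step concerns configuration at the saturated ring carbon and says nothing about the aryl substituent, so the only guidance is that the carbamate and lactone parts are shared by all three compounds. The step is therefore expected to be small, with no clear direction beyond the scatter, and compound 3 is expected to give 16000 nM in this assay, a range of 6000 nM to 45000 nM, that is a 1.3-fold higher number from compound 2 to compound 3 (0.11 log units; within the scatter).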

Compound 3, half-maximal cytotoxic concentration: 22300 nM
The estimate for compound 3 lay 1.4-fold (0.14 log units) below the measured number; low and high end bracket the measured number.
By their numbers in this assay, from the lowest: compounds 2, 1 and 3 (each within the scatter of the next).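

Hydrogen in place of iodo, on an aromatic carbon para to a large group, is the first change shown on the aromatic ring, and in this assay it stays within the usual scatter (a 1.8-fold higher number from compound 2 to compound 3 (0.25 log units; within the scatter)). The earlier pair spoke only to configuration at a saturated ring carbon, whereas this pair shows that, for compound 2, the iodo group can be lost without a step beyond the scatter. Nothing at hand accounts for the size of this step.

The compounds shown leave open whether an amine, a methoxy group or a carboxylic acid at this place would give a step beyond the scatter. They also leave open whether the same exchange of iodo for hydrogen would read alike in the configuration of compound 1.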